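This account rests on a few compounds, and the source may have more. Where it says the series, first, only, none or still open, it means among the compounds named here.

In a functional assay on HCT-15 cells (Homo sapiens) for cytotoxicity, read by ELISA, with a stated time of 4 days (a higher number here means a weaker inhibitor, a lower number a stronger inhibitor), compound 1 `Cc1ccsc1-c1cc(-c2ccco2)cc(-c2ccccc2Cl)n1` gives 540 nM and compound 2 `Cc1ccccc1-c1cc(-c2ccoc2)cc(-c2ccc(Cl)s2)n1` gives 990 nM. These two numbers lie within the usual scatter of each other, so compound 2 stands level with compound 1. Compound 3 `Cc1ccc(-c2cc(-c3ccoc3)cc(-c3ccc(Cl)s3)n2)cc1` has the same atoms as compound 2, joined differently, with 4-methylphenyl in place of 2-methylphenyl on an aromatic carbon. For the measured compounds named here, no measured step between closely matched compounds is available as a guide, so no change beyond the scatter is expected, and the expected step is a 1.1-fold lower number from compound 2 to compound 3 (0.04 log units; within the scatter). For compound 3, the estimated value is 900 nM, with an expected range of 300 nM to 3000 nM.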

Compound 3, half-maximal inhibitory concentration: 1170 nM
The estimate for compound 3 lay 1.3-fold (0.11 log units) below the measured number; the range from low to high includes it.
By their numbers in this assay, from the lowest: compounds 1, 2 and 3 (each within the scatter of the next, the first and the last beyond it).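

In this assay, for the compounds shown here, 4-methylphenyl in place of 2-methylphenyl gives a 1.2-fold higher number from compound 2 to compound 3 (0.07 log units; within the scatter) and so provides the first closely matched pair in this set. At this position next to the ring nitrogen, with the 5-chlorothiophen-2-yl and furan-3-yl groups unchanged, the two methylphenyl groups cannot be told apart. Nothing available here explains this result. As far as these compounds go, whether an amine, a carboxylic acid or a longer chain in place of the methylphenyl group would move the number beyond the scatter stays open. So does whether this swap would read the same with other groups on the shared core.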